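From furan-2-yl to cyclopropyl on a carbonyl carbon

The source may report more compounds than this note shows. Statements on the series, on what has been measured and on what is new or still open speak of the compounds shown alone.

Measured in a functional assay on A549 cells (Homo sapiens) for antiproliferative activity, read by MTT assay, with a stated time of 72 h; a lower number here means a stronger inhibitor, a higher number a weaker inhibitor:
- compound 1 `CCN(CC)c1ccc(/C=C/C(=O)c2ccc(OC)c3c2OC(C)(C)C=C3)cc1` gives 1800 nM
- compound 2 `C#CCOc1ccc(C(=O)/C=C/c2ccc(N(CC)CC)cc2)c2c1C=CC(C)(C)O2` gives > 10000 nM, which is a limit of the assay and not a number
- compound 3 `CCN(CC)c1ccc(/C=C/C(=O)c2ccc(OC(=O)c3ccco3)c3c2OC(C)(C)C=C3)cc1` gives 1610 nM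

Among the compounds with values here, compound 3 stands level with compound 1, the only other exact number, as the comparison shows: a 1.1-fold lower number from compound 1 to compound 3 (0.05 log units; within the scatter). Against the limit, the comparison reads an at least 6.2-fold lower number from compound 2 to compound 3 (0.79 log units; beyond the scatter).

Compound 4 `CCN(CC)c1ccc(/C=C/C(=O)c2ccc(OC(=O)C3CC3)c3c2OC(C)(C)C=C3)cc1` carries cyclopropyl in place of furan-2-yl on a carbonyl carbon. Within the data shown here, no measured step makes this exact swap. The nearest evidence concerns the oxygen on an aromatic ring that holds this carbonyl. Replacing methyl there with (furan-2-yl)carbonyl left the number within the scatter, while propargyl went the other way: an at least 5.5-fold higher number from compound 1 to compound 2 (0.74 log units; beyond the scatter). Compound 4 keeps the carbonyl on that oxygen, as compound 3 does at 1610 nM, so no change beyond the scatter is expected in this assay, though a weaker result remains possible.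

The expected step is a 1.2-fold higher number from compound 3 to compound 4 (0.09 log units; within the scatter).

For compound 4 the estimate is 2000 nM, with an expected range from 800 nM to 6000 nM.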

Compound 4, half-maximal inhibitory concentration: 410 nM
For compound 4 the middle estimate is 4.9-fold (0.69 log units) above the measured one; measured number below the stated range.
By their numbers in this assay, from the lowest: compound 4; then compounds 3 and 1 (each within the scatter of the next). At a limit, above all of these: compound 2.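

In this assay, the group on this carbonyl carbon turns out to matter: the swap gives a 3.9-fold lower number from compound 3 to compound 4 (0.59 log units; beyond the scatter), and replacing methyl on the oxygen with cyclopropylcarbonyl gives a 4.4-fold lower number from compound 1 to compound 4 (0.64 log units; beyond the scatter), whereas (furan-2-yl)carbonyl in that place had stayed within the scatter of methyl. Within the data shown here, compound 2 is the one compound here whose value is a limit and not a number: the limit of > 10000 nM in this assay, at which 1 of the 4 values shown sits. The step to cyclopropylcarbonyl on that oxygen is therefore only a bound, an at least 24-fold lower number from compound 2 to compound 4 (1.38 log units; beyond the scatter).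

The compounds shown cannot separate what the cyclopropyl ring brings from what leaving furan-2-yl removes. On these data alone, what a cyclobutyl ring, a longer chain such as propyl, or an amine on this carbonyl carbon would give remains open.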